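The source may hold more compounds than are shown below. What is called first, only, known or untested is meant among the compounds shown, and "the series" means these compounds.

Values in a functional assay on BaF3 cells (Mus musculus) for antiproliferative activity, with a stated time of 48 h; on this read-out lower numbers stand for stronger inhibition and higher numbers for weaker inhibition:
- Compound 1 `CC(=O)N1CCN([C@H]2C[C@@H](n3cc(-c4ccc(Cl)c(O)c4)c4c(N)ncnc43)C2)CC1`: 3700 nM
- Compound 2 `COc1cc(-c2cn([C@H]3C[C@@H](N4CCN(C(C)=O)CC4)C3)c3ncnc(N)c23)ccc1Cl`: > 10000 nM (a limit, not a number)
- Compound 3 `CC(=O)N1CCN([C@H]2C[C@@H](n3cc(-c4ccc(O)cc4)c4c(N)ncnc43)C2)CC1`: > 10000 nM (a limit, not a number)

Compound 3 sits at the limit of > 10000 nM in this assay, at which 2 of the 3 values shown sit. Compound 4 `CC(=O)N1CCN([C@H]2C[C@@H](n3cc(-c4ccc(Cl)c(N)c4)c4c(N)ncnc43)C2)CC1` has 3-amino-4-chlorophenyl in place of 4-hydroxyphenyl on an aromatic carbon. Its new group differs from the 4-chloro-3-hydroxyphenyl of compound 1 only in having amino instead of hydroxy. The closest guide is therefore an at least 2.7-fold higher number from compound 1 to compound 3 (0.43 log units; beyond the scatter), and this is read in reverse. The other relevant change, an at least 2.7-fold higher number from compound 1 to compound 2 (0.43 log units; beyond the scatter), shows that a methyl on the oxygen also gave a higher number. As far as these compounds go, the amino swap itself is untested, so a modest move to a lower number is expected, with wide uncertainty. The expected change is an at least 2.2-fold lower number from compound 3 to compound 4 (0.34 log units; beyond the scatter). For compound 4 the estimate is 4500 nM, with an expected range of 1300 nM to 15000 nM.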

Compound 4, half-maximal inhibitory concentration: 4600 nM
Compound 4: middle estimate off by 1.0-fold (0.01 log units), on the low side; measured number inside the range.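

At this position, amino and hydroxy cannot be told apart in this assay: the swap gives a 1.2-fold higher number from compound 1 to compound 4 (0.09 log units; within the scatter). Amino in place of methoxy gives an at least 2.1-fold lower number from compound 2 to compound 4 (0.33 log units; beyond the scatter), and 3-amino-4-chlorophenyl in place of 4-hydroxyphenyl gives an at least 2.1-fold lower number from compound 3 to compound 4 (0.33 log units; beyond the scatter), so a second group with a hydrogen on the atom attached to the ring matches the hydroxy compound, not the methoxy one. Both of these steps start from a limit, so their full size stays unknown: the limit of > 10000 nM in this assay, at which 2 of the 4 values shown sit.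

Still open, as far as these compounds go, is whether a methylamino or acetamido group in place of the amino would keep this level. Also open, from the compounds shown here alone, is whether fluorine or methyl could stand in for the chlorine.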